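Shortening the alkyl group on the core of compound 3

This account rests on a few compounds, and the source may have more. Where it says the series, first, only, none or still open, it means among the compounds named here.

Measured so far:
compound 1, `Cc1nc2c(N)ncnc2n1[C@@H]1O[C@H](CN(C)CCN)[C@@H](O)[C@H]1O`, 88000 nM
compound 2, `CN(CCCCON)C[C@H]1O[C@@H](n2cnc3c(N)ncnc32)[C@H](O)[C@@H]1O`, 18 nM
compound 3, `CCc1nc2c(N)ncnc2n1[C@@H]1O[C@H](CN(C)CCCCON)[C@@H](O)[C@H]1O`, 15 nM

In an assay on isolated protein for inhibition of S-adenosylmethionine decarboxylase proenzyme (Homo sapiens) (a lower number here means a stronger inhibitor, a higher number a weaker inhibitor), compound 3 gives the lowest number of the three; compound 2 sits within the scatter of it, while compound 1 lies far above both. Compound 4, `Cc1nc2c(N)ncnc2n1[C@@H]1O[C@H](CN(C)CCCCON)[C@@H](O)[C@H]1O`, differs from compound 3 in one place: hydrogen in place of methyl on a saturated chain carbon bound to an aromatic carbon. Compound 1 carries the same methyl on its core, but its side chain also differs from that of compound 4, so its value speaks only for the chain and not for this change. Among the measured compounds shown here, the one step that bears on the ring substituent is a 1.2-fold lower number from compound 2 to compound 3 (0.08 log units; within the scatter), which shows that adding an ethyl at this carbon changes little. A methyl, intermediate between hydrogen and ethyl, is therefore expected to do likewise, and the step of a 1.1-fold higher number from compound 3 to compound 4 (0.03 log units; within the scatter) is expected to stay within the scatter. Compound 4 is estimated at 16 nM, with a range from 7 nM to 40 nM.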

Compound 4, half-maximal inhibitory concentration: 5 nM
Beside the measured number, compound 4's estimate is 3.2-fold (0.51 log units) above it; measured number outside the range, below it.
By their numbers in this assay, from the lowest: compound 4; then compounds 3 and 2 (each within the scatter of the next); then compound 1.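

In this assay, replacing the ethyl with a methyl gives a 3.0-fold lower number from compound 3 to compound 4 (0.48 log units; beyond the scatter) and so shows that this position does respond to the group it carries, which the earlier step from hydrogen to ethyl did not reveal. The step of a 3.6-fold lower number from compound 2 to compound 4 (0.56 log units; beyond the scatter) places the methyl apart from hydrogen as well, while hydrogen and ethyl remain within the scatter of each other, so no steady trend runs from hydrogen through methyl to ethyl, and compound 4 alone goes against one. With the methyl held constant on the core, the side chain matters far more, as an 18000-fold lower number from compound 1 to compound 4 (4.25 log units; beyond the scatter) shows for the change at the chain end. Going by these compounds, whether a propyl, a cyclopropyl or an amine on this aromatic carbon would match the methyl remains open. The compounds shown offer no explanation for why the methyl stands apart from both hydrogen and ethyl.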